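Trifluoromethyl for Methyl in a Lipoxygenase Inhibitor Series

A few compounds are considered here, and "the series" means these few. Any claim that something is new, unique, unknown or untested is made for them only; others in the source may bear on it.

Within the data shown here, compound 2 `CCCCC(Sc1ccc(OCCCOc2cccc(C)c2)cc1)C(=O)O` is the one member of this set with a numerical result: in an assay on isolated protein for inhibition of Polyunsaturated fatty acid 5-lipoxygenase (Homo sapiens), read by HPLC, with a stated time of 15 min, in the presence of a further agent that is not named here (on this read-out higher numbers stand for weaker inhibition and lower numbers for stronger inhibition), compound 2 gives 4800 nM. Compound 1 `Cc1cccc(OCCCOc2ccc(CCC(=O)O)cc2)c1C` in this assay gives > 10000 nM, which is a limit of the assay rather than a number. Compound 3 `Cc1cccc(OCCCOc2ccc(SCC(=O)O)cc2)c1C` in this assay gives > 10000 nM, also a limit. Between them stands a step that the two limits leave unreadable from compound 1 to compound 3, and the limit of > 10000 nM in this assay, at which 2 of the 3 values shown sit, is where two of the three results sit. Compound 4 `CCCCC(Sc1ccc(OCCCOc2cccc(C(F)(F)F)c2)cc1)C(=O)O` differs from compound 2 by trifluoromethyl in place of methyl on an aromatic carbon. Among the measured compounds shown here, no measured step touches this change, so nothing among the measured compounds argues for a shift beyond the scatter; in this assay the expected outcome is a 1.2-fold lower number from compound 2 to compound 4 (0.08 log units; within the scatter). Compound 4 is therefore estimated at 4000 nM, within 1500 nM to 12000 nM.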

Compound 4, half-maximal inhibitory concentration: 1600 nM
Beside the measured number, compound 4's estimate is 2.5-fold (0.40 log units) above it; low and high end bracket the measured number.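

In this assay, trifluoromethyl in place of methyl on the aromatic carbon gives a 3.0-fold lower number from compound 2 to compound 4 (0.48 log units; beyond the scatter). Among these compounds, this is the first readable step at this position, and it shows that the 3-methylphenyl group can be changed to 3-(trifluoromethyl)phenyl with a shift beyond the usual scatter, which the earlier compounds could not show. Nothing among the data shown accounts for this shift.

The evidence for this position rests on this single pair of compounds. From the compounds shown here alone, it remains open how a chlorine atom, a nitrile or an ethyl group in the same place would compare, and whether trifluoromethyl would have a similar effect with the other acid side chains.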